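Taking the Fluoro Off Compound 3

The source may report more compounds than this note shows. Statements on the series, on what has been measured and on what is new or still open speak of the compounds shown alone.

Of the compounds shown here, three with a shared core have been measured in a functional assay on KB-VIN10 cells (Homo sapiens) for inhibition, with a stated time of 72 h; a lower number here means a stronger inhibitor, a higher number a weaker inhibitor. Compound 1 `COc1ccc(S(=O)(=O)N2CCc3cccc(-c4ccco4)c32)cc1`, which carries furan-2-yl, gives 79.2 nM. Compound 2 `COc1ccc(S(=O)(=O)N2CCc3cccc(-c4ccc(F)cc4)c32)cc1`, which carries 4-fluorophenyl, gives 94.6 nM. Compound 3 `COc1ccc(S(=O)(=O)N2CCc3cccc(-c4cccc(F)c4)c32)cc1`, which carries 3-fluorophenyl, gives 92.4 nM, so it lies within the usual scatter of both others.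

The next compound, compound 4 `COc1ccc(S(=O)(=O)N2CCc3cccc(-c4ccccc4)c32)cc1`, has hydrogen in place of fluoro on an aromatic carbon. Among the measured compounds shown here, no measured step makes exactly this change, so the evidence is indirect. Moving the fluoro gives a 1.0-fold lower number from compound 2 to compound 3 (0.01 log units; within the scatter). Swapping furan-2-yl for a fluorophenyl group gives a 1.2-fold higher number from compound 1 to compound 2 (0.08 log units; within the scatter) and a 1.2-fold higher number from compound 1 to compound 3 (0.07 log units; within the scatter). For the measured compounds named here, all three steps stay within the scatter, so nothing so far suggests that a change at this group shifts the number much. No step beyond the scatter is therefore expected in this assay, and the expected step is a 1.0-fold lower number from compound 3 to compound 4 (0.01 log units; within the scatter). For compound 4 the estimated value is 90 nM, with an expected range of 55 nM to 145 nM.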

Compound 4, half-maximal inhibitory concentration: 107 nM
Estimate against measurement, compound 4: 1.2-fold (0.08 log units) below, and the stated range covers the measured number.
By their numbers in this assay, from the lowest: compounds 1, 3, 2 and 4 (each within the scatter of the next).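

In this assay the fluoro can now be removed outright rather than moved, and hydrogen in its place gives a 1.2-fold higher number from compound 3 to compound 4 (0.06 log units; within the scatter) and a 1.1-fold higher number from compound 2 to compound 4 (0.05 log units; within the scatter) so the fluoro is not needed to keep the number in this range. Plain phenyl in place of furan-2-yl gives a 1.4-fold higher number from compound 1 to compound 4 (0.13 log units; within the scatter) which is the widest gap among these four compounds yet still leaves them inseparable. No measurement at hand explains why this position accepts such swaps.

On these data alone, all four groups at this position are aromatic rings, so it remains open whether an amine, a carboxylic acid or a longer chain there would keep the number in this range. As far as these compounds go, whether a hydroxyl in place of the methoxy group would do the same also remains open.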